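Losing one hydroxymethyl from a polyol side chain

The source may report more compounds than this note shows. Statements on the series, on what has been measured and on what is new or still open speak of the compounds shown alone.

- compound 1 `COc1cc(C2CN(C(=O)c3cc(OCCO)ccn3)C2)ccc1OCc1ccc(C2CC2)cc1`: 64%
- compound 2 `COc1cc(C2CN(C(=O)c3cc(COCC(CO)(CO)CO)ccn3)C2)ccc1OCc1ccc(C2CC2)cc1`: 81%

In an ADME assay on S9 fraction from liver (Mus musculus, strain CD-1) for metabolic stability, read by LC-MS, using NADPH, with stated times of 5 min and 60 min, tested at 5 uM (a lower number here means that less of the compound is left, a higher number that more of the compound is left), compound 2 holds the higher of the two numbers, at 81%. Compound 3 `COc1cc(C2CN(C(=O)c3cc(COCC(CO)CO)ccn3)C2)ccc1OCc1ccc(C2CC2)cc1` has not been measured yet and differs from compound 2 in one place: hydrogen in place of hydroxymethyl on a saturated chain carbon bound to three saturated chain carbons. Hydrogen stands in place of hydroxymethyl on a saturated chain carbon bound to three saturated chain carbons, which turns 3-hydroxy-2,2-bis(hydroxymethyl)propoxy into 3-hydroxy-2-(hydroxymethyl)propoxy.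

Within the data shown here, only one measured step offers any guide, and it is a number 17 percentage points higher from compound 1 to compound 2 (beyond the scatter). That step exchanged 2-hydroxyethoxy for the whole (3-hydroxy-2,2-bis(hydroxymethyl)propoxy)methyl group, a larger change than the one now in question. Two compounds establish no rule, so this guide is weak. A smaller move back towards the number of compound 1 seems the most likely outcome, and it may stay inside the scatter. The expected change is a number 5 percentage points lower from compound 2 to compound 3 (within the scatter). Compound 3 is estimated at 76%, with an expected range from 63% to 88%.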

Compound 3, percent of the compound remaining: 66%
Compound 3: the middle estimate sits 10 percentage points above what was measured; low and high end bracket the measured number.
By their numbers in this assay, from the lowest: compounds 1 and 3 (each within the scatter of the next); then compound 2.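

In this assay the hydroxymethyl on the saturated chain carbon bound to three saturated chain carbons proves to count for a great deal: putting hydrogen there gives a number 15 percentage points lower from compound 2 to compound 3 (beyond the scatter) and so takes back most of the earlier gain, a number 17 percentage points higher from compound 1 to compound 2 (beyond the scatter). The comparison with the smaller side chain sharpens this, since (3-hydroxy-2-(hydroxymethyl)propoxy)methyl in place of 2-hydroxyethoxy on the aromatic carbon gives only a number 2 percentage points higher from compound 1 to compound 3 (within the scatter), so among these three compounds only the 3-hydroxy-2,2-bis(hydroxymethyl)propoxy group of compound 2 stands apart from the others. Among these compounds, nothing available gives a reason why removing this one group moves the number so far.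

The compounds shown leave open whether hydroxymethyl itself is needed at this carbon, or whether another group there, such as an amine, a carboxylic acid or a methyl, would hold the number of compound 2 as well. They also leave open what a longer chain ending in a hydroxyl would do in place of the hydroxymethyl.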